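The source may hold more compounds than are shown below. What is called first, only, known or untested is meant among the compounds shown, and "the series" means these compounds.

The compounds here share one core and differ in the group attached to one amide-type nitrogen. Compound 1 `CC(=O)Nc1cc(NC(=O)Nc2ccc(Cl)nc2)ccc1C` in a functional assay on A375P cells (Homo sapiens) for antiproliferative activity (a higher number here means a weaker inhibitor, a lower number a stronger inhibitor), gives 1100 nM. Compound 2 `Cc1ccc(NC(=O)Nc2cc(Cl)cc(Cl)c2)cc1NC(=O)c1ccccc1` in this assay gives 259 nM. Compound 3 `Cc1ccc(NC(=O)Nc2ccc3c(c2)OCCO3)cc1NC(=O)c1ccccc1` in this assay reaches only a limit, > 30000 nM (the limit of > 30000 nM in this assay, at which 1 of the 3 values shown sits), so compound 3 stands at the weak end of what has been measured. Among the measured compounds shown here, the single step leading there, an at least 110-fold higher number from compound 2 to compound 3 (2.06 log units; beyond the scatter), is large. Compound 4 `Cc1ccc(NC(=O)Nc2ccc(Cl)nc2)cc1NC(=O)c1ccccc1` differs from compound 3 by 6-chloropyridin-3-yl in place of 2,3-dihydro-1,4-benzodioxin-6-yl on an amide-type nitrogen; this is the group also carried by compound 1, whose value was 1100 nM. Compound 4 is therefore expected to recover much of the lost activity, a step of an at least 30-fold lower number from compound 3 to compound 4 (1.47 log units; beyond the scatter). Compound 4 is estimated at 1000 nM, with a range from 250 nM to 6000 nM.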

Compound 4, half-maximal inhibitory concentration: 1600 nM
The estimate for compound 4 lay 1.6-fold (0.20 log units) below the measured number; measured number inside the range.
By their numbers in this assay, from the lowest: compound 2; then compounds 1 and 4 (each within the scatter of the next). At a limit, above all of these: compound 3.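

Placing 6-chloropyridin-3-yl on this amide-type nitrogen gives an at least 18-fold lower number from compound 3 to compound 4 (1.27 log units; beyond the scatter), a size that can only be read as a minimum, as compound 3 reaches only a limit of the assay: the limit of > 30000 nM in this assay, at which 1 of the 4 values shown sits. The same group does not match 3,5-dichlorophenyl, with a 6.2-fold higher number from compound 2 to compound 4 (0.79 log units; beyond the scatter). A change elsewhere, phenyl in place of methyl on a carbonyl carbon, gives a 1.5-fold higher number from compound 1 to compound 4 (0.16 log units; within the scatter), so it makes no readable difference here.

Open, on these data alone, is how a plain phenyl or a 4-methoxyphenyl would behave on this nitrogen. Also open, as far as these compounds go, is whether an amine on the carbonyl carbon would keep this activity.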